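A Nitrile Added Next to the Sulfonamide

The compounds below may be only part of what the source reports. "The series", "measured", "known", "first", "only" and "open" are said of these compounds alone.

Compound 2 `Cc1cccc(S(=O)(=O)N2CCC(N3CCC(C)CC3)CC2)c1` gives 25 nM in a functional assay on DLD-1 cells (Homo sapiens) for antiproliferative activity, read by CellTiter-Glo, with a stated time of 72 h (a higher number here means a weaker inhibitor, a lower number a stronger inhibitor), the higher of the two plain numbers. Compound 1 `CC1CCN(C2CCN(S(=O)(=O)c3cccc(-c4ccc(F)cc4)c3)CC2)CC1` gives 12 nM in this assay, and the step is a 2.1-fold higher number from compound 1 to compound 2 (0.32 log units; beyond the scatter). Compound 3 `CC1CCN(C2CCN(S(=O)(=O)c3cccc(C(F)(F)F)c3)CC2)CC1` returns only a limit in this assay, > 5000 nM, so no exact number exists for it. From compound 2 to compound 4 `Cc1ccc(C#N)c(S(=O)(=O)N2CCC(N3CCC(C)CC3)CC2)c1` the change is cyano in place of hydrogen on an aromatic carbon. Within the data shown here, no measured step adds a group in this way: both a 2.1-fold higher number from compound 1 to compound 2 (0.32 log units; beyond the scatter) and an at least 200-fold higher number from compound 2 to compound 3 (2.30 log units; beyond the scatter) swap the group already present, and the latter shows a small swap can cost a great deal. A modest shift toward a weaker inhibitor is therefore expected, a 2.0-fold higher number from compound 2 to compound 4 (0.30 log units; within the scatter). Compound 4 is estimated at 50 nM, within 15 nM to 200 nM.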

Compound 4, half-maximal inhibitory concentration: 285 nM
Compound 4: middle estimate off by 5.7-fold (0.76 log units), on the low side; measured number outside the range, above it.
By their numbers in this assay, from the lowest: compound 1; then compound 2; then compound 4. At a limit, above all of these: compound 3.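

The earlier steps shown here all swapped a group already on the ring, whereas this one replaces a hydrogen at a second ring position, ortho to a large group and para to a methyl group. Adding cyano there gives an 11-fold higher number from compound 2 to compound 4 (1.06 log units; beyond the scatter) in this assay, so this position also affects the number strongly. Nothing measured here explains the size of this step.

From the compounds shown here alone, whether an amine, a carboxylic acid or a methoxy group at this position would give a smaller step remains open, as does the effect of cyano here with the methyl group absent.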